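A few compounds are considered here, and "the series" means these few. Any claim that something is new, unique, unknown or untested is made for them only; others in the source may bear on it.

Measured so far in a functional assay on U-251 cells (Homo sapiens) for antiproliferative activity, read by MTT assay, with a stated time of 72 h; a lower number here means a stronger inhibitor, a higher number a weaker inhibitor:
- compound 1 `O=C(Nc1ccc(Cl)c(-c2nnc3c(Cl)cccn23)c1)c1ccc(C(F)(F)F)cc1Cl` gives > 100000 nM, a limit of the assay.
- compound 2 `O=C(Nc1ccc(Cl)c(-c2nnc3c(Cl)cccn23)c1)c1ccc(Cl)cc1` gives > 100000 nM, a limit of the assay.
- compound 3 `CS(=O)(=O)c1ccc(C(=O)Nc2ccc(Cl)c(-c3nnc4c(Cl)cccn34)c2)cc1` gives > 100000 nM, a limit of the assay.

The step from compound 2 to compound 3 is a step that the two limits leave unreadable from compound 2 to compound 3, since both ends are limits. Compound 3 therefore stands nowhere on a numerical scale: its value is a limit, and the same holds for the two other values shown, as summarised by the limit of > 100000 nM in this assay, at which 3 of the 3 values shown sit.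

Compound 4 `CS(=O)(=O)c1ccc(C(=O)Nc2ccc(Cl)c(-c3nnc4c(Cl)cccn34)c2)c(Cl)c1` differs from compound 3 by chloro in place of hydrogen on an aromatic carbon. Going by the values given here, no measured step bears directly on this change. The nearest comparison is compound 1, which carries a chloro on the same aromatic carbon together with a trifluoromethyl and also gives only a limit in this assay. Nothing among the shown values suggests that adding a chloro moves a compound of this series off the limit. Compound 4 is thus expected to remain at the limit, and the step that the limit leaves unreadable from compound 3 to compound 4 is estimated as none beyond the scatter. The estimate for compound 4 is 150000 nM, with a range from 40000 nM to 600000 nM.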

Compound 4, half-maximal inhibitory concentration: 44600 nM
Compound 4: the middle estimate sits 3.4-fold (0.53 log units) above what was measured; measured number inside the range.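

In this assay, chloro in place of hydrogen on the aromatic carbon ortho to a large group gives an at least 2.2-fold lower number from compound 3 to compound 4 (0.35 log units; beyond the scatter), and compound 4 is the only compound shown that has a number rather than a limit. The chloro does not do this alone: with it kept, methylsulfonyl in place of trifluoromethyl gives an at least 2.2-fold lower number from compound 1 to compound 4 (0.35 log units; beyond the scatter), so both changes count, and both sizes are lower bounds. The earlier step cannot be read, and most of the series stays at one limit: the limit of > 100000 nM in this assay, at which 3 of the 4 values shown sit.

On these data alone, the true size of both steps remains unknown. Also open, as far as these compounds go, is whether a fluoro or a methyl on the same carbon, or an amine or a carboxylic acid in place of the methylsulfonyl, would lower the number further.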